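The source may report more compounds than this note shows. Statements on the series, on what has been measured and on what is new or still open speak of the compounds shown alone.

Compound 2, `CCOC(=O)C1=C(C)N/C(=C/c2cc(C)n(-c3cccc(OC)c3)c2C)C1=O`, stands lowest of the two numbers in a physicochemical assay for lipophilicity, read by HPLC, at pH 7.4 (on this read-out higher numbers stand for higher lipophilicity and lower numbers for lower lipophilicity), with compound 2 at 2.9; its nearest neighbour, compound 1, `CCOC(=O)C1=C(C)N/C(=C/c2cc(C)n(-c3ccc(OC)cc3)c2C)C1=O`, gives 3, and the step of a number 0.10 log units lower from compound 1 to compound 2 (within the scatter) lies within the scatter. Compound 3, `CCOC(=O)C1=C(C)N/C(=C/c2cc(C)n(-c3cccnc3)c2C)C1=O`, carries the change (pyridin-3-yl in place of 3-methoxyphenyl on an aromatic nitrogen). Going by the values given here, no measured step covers this exchange of ring; the one step on record, from a 4-methoxyphenyl to a 3-methoxyphenyl, leaves this assay unmoved. The exchange of an all-carbon ring for one with a hetero atom is nonetheless expected to lower this assay, by about a number 1.20 log units lower from compound 2 to compound 3 (beyond the scatter). Compound 3 is therefore estimated at 1.7, between 1.1 and 2.3.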

Compound 3, distribution coefficient: 2.1
Compound 3: middle estimate off by 0.40 log units, on the low side, within the range that was stated.
By their numbers in this assay, from the lowest: compound 3; then compounds 2 and 1 (each within the scatter of the next).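

On an aromatic nitrogen, this assay proved sensitive to the ring itself, not only to where a methoxy group sits on it: pyridin-3-yl in place of 3-methoxyphenyl gives a number 0.80 log units lower from compound 2 to compound 3 (beyond the scatter) and, in place of 4-methoxyphenyl, gives a number 0.90 log units lower from compound 1 to compound 3 (beyond the scatter) as the second step beyond the scatter. Nothing on record accounts for the size of these steps. The compounds shown leave open how pyridin-2-yl or pyridin-4-yl would read here, and whether a phenyl ring bearing an amine or a carboxylic acid would read lower still.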